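A few compounds are considered here, and "the series" means these few. Any claim that something is new, unique, unknown or untested is made for them only; others in the source may bear on it.

Measured compounds in a functional assay on KB cells (Homo sapiens) for antiproliferative activity, read by sulforhodamine B assay, with a stated time of 3 days; on this read-out higher numbers stand for weaker inhibition of growth and lower numbers for stronger inhibition of growth:
Compound 1, `COc1ccc(N2CCN(C)CC2)cc1Nc1ncc(F)c(Nc2ccc(F)cc2)n1`, gives 960 nM.
Compound 2, `COc1ccc(NC(=O)c2cccc(Nc3ncc(F)c(Nc4ccc(F)cc4)n3)c2)cc1`, reaches only a limit of the assay, > 10000 nM.
Compound 3, `CN1CCC(C(=O)Nc2cccc(Nc3ncc(F)c(Nc4ccc(F)cc4)n3)c2)CC1`, gives 1700 nM.

Compound 2 therefore stands at the limit of > 10000 nM in this assay, at which 1 of the 3 values shown sits, with no number of its own. For the measured compounds named here, the one measured step that touches compound 2 is an at least 5.8-fold lower number from compound 2 to compound 3 (0.76 log units; beyond the scatter); it exchanges the whole (4-methoxyphenyl)carbamoyl group and says nothing about a change that keeps the carbamoyl and alters only the aryl on it. Compound 4, `O=C(Nc1cc(Cl)cc(Cl)c1)c1cccc(Nc2ncc(F)c(Nc3ccc(F)cc3)n2)c1`, is such a change: 3,5-dichlorophenyl in place of 4-methoxyphenyl on an amide-type nitrogen. Going by the values given here, no measured pair shows an aryl-for-aryl exchange on the amide-type nitrogen, so the expectation in this assay rests on compound 2 alone. Compound 4 is expected to stay close to where compound 2 sits, with the estimated step of a number no higher from compound 2 to compound 4 (the limit leaves the size open) not clearly beyond the scatter and a real chance that compound 4 would also be expected to end at a limit of the assay. The estimate for compound 4 is 10000 nM, between 3000 nM and 30000 nM.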

Compound 4, concentration for 50% growth inhibition: 20100 nM
Beside the measured number, compound 4's estimate is 2.0-fold (0.30 log units) below it, and the stated range covers the measured number.
By their numbers in this assay, from the lowest: compounds 1 and 3 (each within the scatter of the next); then compound 4.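

In this assay, for the compounds shown here, compound 4 gives 20100 nM, the first actual number for an aryl on the amide-type nitrogen of this carbamoyl. The step from compound 2 to compound 4 cannot be read, because compound 2 has no number of its own, only a limit of the assay: the limit of > 10000 nM in this assay, at which 1 of the 4 values shown sits.

Putting (3,5-dichlorophenyl)carbamoyl in place of ((1-methylpiperidin-4-yl)carbonyl)amino on an aromatic carbon gives a 12-fold higher number from compound 3 to compound 4 (1.07 log units; beyond the scatter), so with 3,5-dichlorophenyl as with 4-methoxyphenyl, the aryl carbamoyl stays weaker than compound 3 in growth inhibition.

From the compounds shown here alone, whether the 3,5-dichlorophenyl and 4-methoxyphenyl carbamoyls really differ remains open. Also open, going by these compounds, is whether any aryl on this nitrogen can recover growth inhibition, for example one carrying a dimethylamino group or a carboxylic acid.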